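This account rests on a few compounds, and the source may have more. Where it says the series, first, only, none or still open, it means among the compounds named here.

In a functional assay on A549 cells (Homo sapiens) for inhibition, read by MTT assay, with a stated time of 48 h (a higher number here means a weaker inhibitor, a lower number a stronger inhibitor), compound 1 `COc1ccc2c(=O)c(/C=C/C(=O)Nc3cccc(C)c3)coc2c1` gives > 100000 nM, which is a limit of the assay and not a number. Its position on these data is therefore (the limit of > 100000 nM in this assay, at which 1 of the 3 values shown sits).

Two close relatives share its core and differ only in the group on the amide-type nitrogen. Compound 2 `COc1ccc2c(=O)c(/C=C/C(=O)Nc3ccccc3Cl)coc2c1`, with 2-chlorophenyl, gives 29900 nM. Compound 3 `COc1ccc2c(=O)c(/C=C/C(=O)NCc3cccc(F)c3)coc2c1`, with 3-fluorobenzyl, gives 26900 nM. Replacing 3-methylphenyl with 2-chlorophenyl produces an at least 3.3-fold lower number from compound 1 to compound 2 (0.52 log units; beyond the scatter), and replacing it with 3-fluorobenzyl produces an at least 3.7-fold lower number from compound 1 to compound 3 (0.57 log units; beyond the scatter). The two replacements end up level, with a 1.1-fold lower number from compound 2 to compound 3 (0.05 log units; within the scatter).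

Compound 4 `COc1ccc2c(=O)c(/C=C/C(=O)NCc3ccc(F)cc3)coc2c1` has not yet been measured. It also starts from compound 1 and puts 4-fluorobenzyl in place of 3-methylphenyl on the amide-type nitrogen: 4-fluorobenzyl in place of 3-methylphenyl on an amide-type nitrogen. The closest guide is compound 3, which carries 3-fluorobenzyl in the same place and showed an at least 3.7-fold lower number from compound 1 to compound 3 (0.57 log units; beyond the scatter). Both measured replacements moved the number down, and neither compound 2 nor compound 3 goes against that, although two compounds are slender support. A step of similar size in the same direction is therefore expected in this assay, and the expected step is an at least 3.3-fold lower number from compound 1 to compound 4 (0.52 log units; beyond the scatter). For compound 4 the estimated value is 30000 nM, with an expected range from 12000 nM to 80000 nM.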

Compound 4, half-maximal inhibitory concentration: > 100000 nM
Compound 4: no number, only a limit; the forecaster's own chance of this, stated with the estimate: 15%; at least 3.3-fold (0.52 log units) between middle value and limit.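

In this assay, the group on the amide-type nitrogen proves sensitive to a small change: 4-fluorobenzyl in place of 3-fluorobenzyl gives an at least 3.7-fold higher number from compound 3 to compound 4 (0.57 log units; beyond the scatter), although the two groups differ only in where the fluorine sits. A step of similar size appears when 4-fluorobenzyl takes the place of 2-chlorophenyl, with an at least 3.3-fold higher number from compound 2 to compound 4 (0.52 log units; beyond the scatter). Compound 4 gives only a limit of the assay, as compound 1 does, so the step linking them cannot be read, and replacing 3-methylphenyl does not always bring a readable, lower number: the limit of > 100000 nM in this assay, at which 2 of the 4 values shown sit.

How far compound 4 really lies from compound 3 stays unknown, since only a minimum for that gap can be stated, and these few compounds do not explain why the place of the fluorine matters. Also open, as far as these compounds go, is what a plain benzyl group without fluorine, or a longer chain such as phenylethyl, would give on the same amide-type nitrogen, which would show whether the fluorine or the benzyl group itself drives these results.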